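Removing a methyl from a weak cytotoxic linker

A few compounds are considered here, and "the series" means these few. Any claim that something is new, unique, unknown or untested is made for them only; others in the source may bear on it.

Compound 1 `Cn1c(=O)c2c(ncn2CC(=O)OCc2cn(CC3OC(n4ccc(=O)[nH]c4=O)C4OC(C)(C)OC34)nn2)n(C)c1=O`: 6200 nM
Compound 2 `CCn1c(=O)ccn(C2OC(Cn3cc(COC(=O)C(C)n4cnc5c4c(=O)n(C)c(=O)n5C)nn3)C(O)C2O)c1=O`: 62800 nM

In a functional assay on HT-29 cells (Homo sapiens) for cytotoxicity, read by MTT assay, with a stated time of 48 h (a higher number here means a weaker inhibitor, a lower number a stronger inhibitor), compound 2 gives 62800 nM, the higher of the two measured numbers, while compound 1 gives 6200 nM, a difference beyond the usual scatter. Compound 3 `CCn1c(=O)ccn(C2OC(Cn3cc(COC(=O)Cn4cnc5c4c(=O)n(C)c(=O)n5C)nn3)C(O)C2O)c1=O` is not yet measured. It differs from compound 2 by hydrogen in place of methyl on a saturated chain carbon bound to an aromatic nitrogen and a carbonyl carbon. Nothing measured here shows what such a change does, so the step is expected to stay within the scatter, with no clear direction. Compound 3 is expected to give 50000 nM, between 20000 nM and 150000 nM. The expected step is a 1.3-fold lower number from compound 2 to compound 3 (0.10 log units; within the scatter).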

Compound 3, half-maximal inhibitory concentration: 2190 nM
For compound 3 the middle estimate is 23-fold (1.36 log units) above the measured one; measured number outside the range, below it.
By their numbers in this assay, from the lowest: compound 3; then compound 1; then compound 2.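

In this assay, hydrogen in place of methyl on a saturated chain carbon bound to an aromatic nitrogen and a carbonyl carbon gives a 29-fold lower number from compound 2 to compound 3 (1.46 log units; beyond the scatter), so losing this single carbon changes the result strongly. The earlier pair differs in more than one place and could not isolate this position. No available evidence explains the size of this step. Still open, going by these compounds, is whether a longer chain, such as propyl, or an amine on this carbon would keep the lower number of compound 3 or return towards that of compound 2.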